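Swapping a Hydroxy for a Methoxy on a Pyroglutamide Amidine

The compounds below may be only part of what the source reports. "The series", "measured", "known", "first", "only" and "open" are said of these compounds alone.

Of the compounds shown here, three have so far been measured in a functional assay on SH-SY5Y cells (Homo sapiens) for cytotoxicity, read by MTT assay, with stated times of 8 h, 30 min and 12 h, tested at 0.5 uM; a lower number here means a weaker effect, a higher number a stronger effect of the compound at the concentration tested. Compound 1 `COc1ccc(CNC(=N)[C@@H]2CCC(=O)N2Cc2ccccc2)cc1` gives 23.6% in this assay. Among the measured compounds shown here, compound 2 `COc1ccc(CNC(=N)[C@@H]2CCC(=O)N2Cc2ccccc2[N+](=O)[O-])cc1` gives 21.1% in this assay, and the only single-point step recorded so far, a number 2.5 percentage points lower from compound 1 to compound 2 (within the scatter), falls within the scatter of the method. Compound 3 `N=C(NCc1ccc(O)cc1)[C@@H]1CCC(=O)N1Cc1ccc([N+](=O)[O-])cc1` gives 31.3% in this assay, the highest of the three numbers: its gap to compound 1 is within the scatter, while its gap to compound 2 lies beyond it.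

Compound 4 `COc1ccc(CNC(=N)[C@@H]2CCC(=O)N2Cc2ccc([N+](=O)[O-])cc2)cc1` has not yet been measured. It differs from compound 3 by methyl in place of hydrogen on an oxygen on an aromatic ring, so that the 4-hydroxybenzyl group becomes a 4-methoxybenzyl group, the same group carried by compound 1 and compound 2. For the measured compounds named here, no measured step changes a hydroxy to a methoxy, so the recorded step from compound 1 to compound 2 does not bear on this change, and the measured values give no direction to expect. Going by the values given here, the only guide is that all three values sit within a narrow band, and compound 3 sits at its upper edge. Compound 4 is therefore expected to show a step of a number 4.3 percentage points lower from compound 3 to compound 4 (within the scatter), not beyond the scatter. The estimate for compound 4 is 27%, with a range from 16% to 38%.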

Compound 4, a percentage reported as activity, at one concentration (the size of the read-out at that concentration, not a potency): 25.4%
Beside the measured number, compound 4's estimate is 1.6 percentage points above it, within the range that was stated.
By their numbers in this assay, from the lowest: compounds 2, 1, 4 and 3 (each within the scatter of the next, the first and the last beyond it).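

In this assay, among the compounds shown here, turning the 4-hydroxybenzyl group into a 4-methoxybenzyl group gives a number 5.9 percentage points lower from compound 3 to compound 4 (within the scatter) as the first measured step at this oxygen, so adding one methyl here produces no change that can be told apart from the usual variation between repeats. The new compound also gives two readings on the nitro group: moving it from the 2-nitrophenyl to the 4-nitrophenyl arrangement gives a number 4.3 percentage points higher from compound 2 to compound 4 (within the scatter) in this series, and adding it to the plain phenyl ring as a 4-nitrophenyl group gives a number 1.8 percentage points higher from compound 1 to compound 4 (within the scatter) in the same assay, so neither step stands out from that variation. No further measurement is available to explain these steps.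

This is the only hydroxy and methoxy pair shown, so it remains open whether the same swap would behave alike with the 2-nitrophenyl group or the plain phenyl ring. As far as these compounds go, it also remains open whether a larger ethoxy or benzyloxy group on this oxygen, or an amine in place of the hydroxy, would produce a step beyond the scatter.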